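Swapping the benzyl substituent on a nucleoside antiproliferative series

The compounds below may be only part of what the source reports. "The series", "measured", "known", "first", "only" and "open" are said of these compounds alone.

The measured compounds and their values: compound 1 `OC[C@H]1O[C@@H](n2cnc3c(NCc4cccc(F)c4)ncnc32)[C@H](O)[C@@H]1O` gives 7600 nM in a functional assay on K562 cells (Homo sapiens) for antiproliferative activity, with a stated time of 72 h; on this read-out higher numbers stand for weaker inhibition and lower numbers for stronger inhibition; compound 2 `OC[C@H]1O[C@@H](n2cnc3c(NCc4ccc(Br)cc4)ncnc32)[C@H](O)[C@@H]1O` gives 68200 nM; compound 3 `OC[C@H]1O[C@@H](n2cnc3c(NCc4c(F)ccc(F)c4F)ncnc32)[C@H](O)[C@@H]1O` reaches only the assay limit, > 166000 nM.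

Compound 3 therefore stands at the top of the numbers shown: its value is a limit and not a number, as noted in the limit of > 166000 nM in this assay, at which 1 of the 3 values shown sits. The step of an at least 21-fold higher number from compound 1 to compound 3 (1.33 log units; beyond the scatter) was large, and the step of an at least 2.4-fold higher number from compound 2 to compound 3 (0.38 log units; beyond the scatter) was at least modest, so within this small set the 2,3,6-trifluorophenyl group carried the weakest inhibition that could be measured.

Compound 4 `COc1cccc(CNc2ncnc3c2ncn3[C@@H]2O[C@H](CO)[C@@H](O)[C@H]2O)c1O` differs from compound 3 by 2-hydroxy-3-methoxyphenyl in place of 2,3,6-trifluorophenyl on a saturated chain carbon bound to a nitrogen on an aromatic ring. Both measured steps that end at compound 3 ran toward higher numbers; the two other aryl groups, 3-fluorophenyl in compound 1 and 4-bromophenyl in compound 2, gave numbers within the measurable range. Among the compounds with values here, no measured step involves a 2-hydroxy-3-methoxyphenyl group, so the direction of the change from compound 3 to compound 4 is uncertain; the only indication is that leaving the trifluorophenyl group has, in both measured cases, meant a lower number. Compound 4 is therefore expected to give a lower number than the limit of compound 3, a step of an at least 3.3-fold lower number from compound 3 to compound 4 (0.52 log units; beyond the scatter), with an estimated value of 50000 nM and a range from 10000 nM to 200000 nM.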

Compound 4, half-maximal inhibitory concentration: 27900 nM
For compound 4 the middle estimate is 1.8-fold (0.25 log units) above the measured one, within the range that was stated.
By their numbers in this assay, from the lowest: compound 1; then compound 4; then compound 2. At a limit, above all of these: compound 3.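

In this assay, the 2-hydroxy-3-methoxyphenyl group, which unlike the 2,3,6-trifluorophenyl group carries oxygen and a hydrogen-bond donor, returns the series to the measurable range, with an at least 5.9-fold lower number from compound 3 to compound 4 (0.77 log units; beyond the scatter). It also falls inside the span set by the two measured halogenated groups, with a 2.4-fold lower number from compound 2 to compound 4 (0.39 log units; beyond the scatter) and a 3.7-fold higher number from compound 1 to compound 4 (0.56 log units; beyond the scatter), so at this place on a saturated chain carbon bound to a nitrogen on an aromatic ring an oxygen-bearing aryl group improves on the 4-bromophenyl group of compound 2 but does not match the 3-fluorophenyl group of compound 1. Compound 3 remains a limit and not a number, so the step from it fixes only the least possible size of the change: the limit of > 166000 nM in this assay, at which 1 of the 4 values shown sits.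

The compounds shown leave open whether the hydroxyl or the methoxy group of compound 4 sets its place in this order, a question that a 2-hydroxyphenyl or a 3-methoxyphenyl group at the same place would separate. Also open, from the compounds shown here alone, is how an amine or a carboxylic acid on the aryl ring, or a longer chain carrying that ring, would read in this assay.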